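A few compounds are considered here, and "the series" means these few. Any claim that something is new, unique, unknown or untested is made for them only; others in the source may bear on it.

Working notes on the series.

Three amides on a shared core have been measured in an assay on isolated protein for inhibition of phosphodiesterase 4A (Sus scrofa); a lower number here means a stronger inhibitor, a higher number a weaker inhibitor. Compound 1 `COc1ccc(C(=O)Nc2ccccc2C)cc1OC1CCCC1` gives 300 nM. Compound 2 `COc1ccc(C(=O)Nc2ccccc2Br)cc1OC1CCCC1`, which carries bromo in place of methyl on an aromatic carbon, gives 130 nM, a step of a 2.3-fold lower number from compound 1 to compound 2 (0.36 log units; beyond the scatter). Compound 3 `COc1ccc(C(=O)Nc2c(C)nsc2C)cc1OC1CCCC1` gives 500 nM; it differs from compound 1 by 3,5-dimethyl-1,2-thiazol-4-yl in place of 2-methylphenyl on an amide-type nitrogen, and the step of a 1.7-fold higher number from compound 1 to compound 3 (0.22 log units; within the scatter) is a small one, while a 3.8-fold higher number from compound 2 to compound 3 (0.59 log units; beyond the scatter) is a modest one.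

Compound 4 `COc1ccc(C(=O)Nc2c(C)nsc2Br)cc1OC1CCCC1` is not yet measured. It differs from compound 3 by bromo in place of methyl on an aromatic carbon. Going by the values given here, this is the same kind of change as the one from compound 1 to compound 2, but not the same: in the earlier pair the exchange sits on an aromatic carbon of a six-membered aromatic ring of carbon only, ortho to a large group, whereas here it sits on an aromatic carbon of a five-membered aromatic ring with one nitrogen and one sulfur, next to the ring sulfur and next to the ring atom that bears a large group, two ring bonds from the ring nitrogen and from the ring atom that bears a methyl group. The exchange of methyl for bromo has been seen once only, so the surroundings of the two sites are not matched by any further pair.

Among the compounds with values here, the expectation for compound 4 in this assay is a step of about a 2.1-fold lower number from compound 3 to compound 4 (0.32 log units; beyond the scatter), of the same direction and size as the earlier one, because a 2.3-fold lower number from compound 1 to compound 2 (0.36 log units; beyond the scatter) is the only guide available and is a modest step. Compound 4 is therefore estimated at 240 nM, with a range from 100 nM to 600 nM that allows the surroundings of the new site to blunt or sharpen the step.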

Compound 4, half-maximal inhibitory concentration: 500 nM
Beside the measured number, compound 4's estimate is 2.1-fold (0.32 log units) below it; low and high end bracket the measured number.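

In this assay, bromo in place of methyl on the five-membered aromatic ring with one nitrogen and one sulfur gives no change at the digits printed from compound 3 to compound 4 (within the scatter), and the comparison with the same change on the core of compound 1 shows no gap beyond the scatter: the same change on two cores in this assay, a 2.3-fold lower number (0.36 log units; beyond the scatter) from compound 1 to compound 2 and no change at the digits printed (within the scatter) from compound 3 to compound 4, 2.3-fold (0.36 log units) apart, within the scatter of two such steps. Going by these compounds alone, the two steps therefore give no firm sign that the change behaves differently on the two cores, but they do not show that it carries over either, since only one pair on each core is available and the step on the core of compound 1 is beyond the scatter while the new one is not. Exchanging the aromatic group on the amide-type nitrogen gives a 3.8-fold higher number from compound 2 to compound 4 (0.59 log units; beyond the scatter) and a 1.7-fold higher number from compound 1 to compound 4 (0.22 log units; within the scatter), the first a modest step and the second within the scatter, and the 2-bromophenyl amide remains the strongest inhibitor of the four.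

The compounds shown leave open how other groups at this site of the five-membered ring, such as chloro or a nitrile, would compare with methyl and bromo. They also leave open whether the exchange of methyl for bromo gives the same result when the methoxy on the shared core is replaced by a longer chain such as ethoxy.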